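Swapping the aryl group on the urea of a weakly active series

The source may hold more compounds than are shown below. What is called first, only, known or untested is meant among the compounds shown, and "the series" means these compounds.

Compound 1 `Cc1ccc(NC(=O)N[C@H]2CC[C@H](Oc3ccc(F)cc3)CC2)cc1` was tested in a functional assay on CRL2813 cells (Homo sapiens) for cytotoxicity, read by sulforhodamine B assay, with a stated time of 5 days; a lower number here means a stronger inhibitor, a higher number a weaker inhibitor. Compound 1 gives > 20000 nM, which is a limit of the assay rather than a number. Compound 2 `O=C(Nc1ccc(Cl)cc1)N[C@H]1CC[C@H](Oc2ccc(F)cc2)CC1` likewise gives > 20000 nM, again a limit. Among the measured compounds shown here, compound 3 `COc1cccc(NC(=O)N[C@H]2CC[C@H](Oc3ccc(F)cc3)CC2)c1` gives 14000 nM, the one numeric value in the set. The step of an at least 1.4-fold lower number from compound 1 to compound 3 (0.15 log units; that floor lies within the scatter) and the step of an at least 1.4-fold lower number from compound 2 to compound 3 (0.15 log units; that floor lies within the scatter) are thus small, while the step that the two limits leave unreadable from compound 1 to compound 2 cannot be read, since both values sit at the limit of > 20000 nM in this assay, at which 2 of the 3 values shown sit. Compound 4 `O=C(Nc1ccccc1F)N[C@H]1CC[C@H](Oc2ccc(F)cc2)CC1` is the next, unmeasured member. It differs from compound 1 by 2-fluorophenyl in place of 4-methylphenyl on an amide-type nitrogen. Changing the aryl group on this nitrogen has so far moved nothing beyond the scatter, so he expects no step beyond the scatter, a number no higher from compound 1 to compound 4 (the limit leaves the size open). For compound 4 he therefore estimates 20000 nM, with a range from 8000 nM to 50000 nM.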

Compound 4, half-maximal inhibitory concentration: 17500 nM
Compound 4: middle estimate off by 1.1-fold (0.06 log units), on the high side; measured number inside the range.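

The step of a 1.3-fold higher number from compound 3 to compound 4 (0.10 log units; within the scatter) is the only one shown that joins two numeric values, so 2-fluorophenyl and 3-methoxyphenyl can be compared directly on this nitrogen, and they do not separate. The steps of an at least 1.1-fold lower number from compound 1 to compound 4 (0.05 log units; that floor lies within the scatter) and an at least 1.1-fold lower number from compound 2 to compound 4 (0.05 log units; that floor lies within the scatter) give only floors, so no aryl change at this position has yet been shown to go beyond the scatter: the limit of > 20000 nM in this assay, at which 2 of the 4 values shown sit.

The compounds shown leave open whether an amine or a carboxylic acid on this aromatic ring would move the number beyond the scatter.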